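A Hydroxyl-Bearing Aryl Group at the Assay Limit

The source may hold more compounds than are shown below. What is called first, only, known or untested is meant among the compounds shown, and "the series" means these compounds.

In a functional assay on A549 cells (Homo sapiens) for antiproliferative activity, read by MTT assay, with a stated time of 48 h (a higher number here means a weaker inhibitor, a lower number a stronger inhibitor), compound 1 `C/C(=C\CC/C(C)=C/CC[C@@H]1[C@@]2(C)CCC(=O)C(C)(C)[C@H]2CC[C@@]1(C)O)CC/C=C(\C)C(=O)OCc1cn(-c2ccccc2C)nn1` gives > 150000 nM, which is a limit and not a number. Compound 2 `C/C(=C\CC/C(C)=C/CC[C@@H]1[C@@]2(C)CCC(=O)C(C)(C)[C@H]2CC[C@@]1(C)O)CC/C=C(\C)C(=O)OCc1cn(-c2ccccc2F)nn1` gives > 150000 nM, also a limit. That leaves a step that the two limits leave unreadable from compound 1 to compound 2, and compound 2 stands with compound 1 at the limit of > 150000 nM in this assay, at which 2 of the 2 values shown sit. Compound 3 `C/C(=C\CC/C(C)=C/CC[C@@H]1[C@@]2(C)CCC(=O)C(C)(C)[C@H]2CC[C@@]1(C)O)CC/C=C(\C)C(=O)OCc1cn(-c2cccc(O)c2)nn1` carries one change: 3-hydroxyphenyl in place of 2-fluorophenyl on an aromatic nitrogen. With no measured step size to carry over, no clear shift is expected in this assay, and a further limit is quite possible. The expected step is a number no higher from compound 2 to compound 3 (the limit leaves the size open). For compound 3 the estimated value is 150000 nM, within a range of 60000 nM to 300000 nM.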

Compound 3, half-maximal inhibitory concentration: 42800 nM
Compound 3: middle estimate off by 3.5-fold (0.54 log units), on the high side, and the stated range ends above it.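

The aryl group on this aromatic nitrogen can move the read-out in this assay: 3-hydroxyphenyl gives an at least 3.5-fold lower number from compound 2 to compound 3 (0.54 log units; beyond the scatter), and an at least 3.5-fold lower number from compound 1 to compound 3 (0.54 log units; beyond the scatter). Compound 3 is the only one of the three with a measured number, while 2-methylphenyl and 2-fluorophenyl stay at a limit of the assay: the limit of > 150000 nM in this assay, at which 2 of the 3 values shown sit.

The hydroxyl and its place on the ring change together here, and the compounds shown do not separate the two. On these data alone, whether 3-methoxyphenyl or 3-aminophenyl would read the same stays open, as does the step between compound 1 and compound 2, which cannot be read from two limits.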